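From Fluorophenyl to Dichlorophenyl in an Antiproliferative Series

The compounds below may be only part of what the source reports. "The series", "measured", "known", "first", "only" and "open" are said of these compounds alone.

Compound 1 `O=[N+]([O-])c1ccc(Nc2nccc(-c3ccc(Br)cc3)n2)cc1`: 76000 nM
Compound 2 `Cc1ccc(-c2ccnc(Nc3ccc(Cl)cc3Cl)n2)cc1`: 164000 nM
Compound 3 `O=[N+]([O-])c1ccc(Nc2nccc(-c3ccc(F)cc3)n2)cc1`: 84000 nM

In a functional assay on A549 cells (Homo sapiens) for antiproliferative activity, read by MTT assay (on this read-out lower numbers stand for stronger inhibition and higher numbers for weaker inhibition), compound 3 gives 84000 nM, a number within the scatter of those of both compound 1 and compound 2. Compound 4 `O=[N+]([O-])c1ccc(Nc2nccc(-c3ccc(Cl)cc3Cl)n2)cc1` differs from compound 3 by one change, 2,4-dichlorophenyl in place of 4-fluorophenyl on an aromatic carbon. Going by the values given here, only one measured step bears on this place, a 1.1-fold higher number from compound 1 to compound 3 (0.04 log units; within the scatter), in which fluoro replaces bromo on an aromatic carbon. That step stays within the scatter, but it is a single exchange and does not cover the full change made here. The data therefore give no sign of a sizeable step in this assay and no firm direction, so none beyond the scatter is expected, though with wide uncertainty. The estimated change is a 1.1-fold lower number from compound 3 to compound 4 (0.05 log units; within the scatter). For compound 4 the expected value is 75000 nM, with an estimated range from 35000 nM to 160000 nM.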

Compound 4, half-maximal inhibitory concentration: 119000 nM
Compound 4: middle estimate off by 1.6-fold (0.20 log units), on the low side, and the stated range covers the measured number.
By their numbers in this assay, from the lowest: compounds 1, 3, 4 and 2 (each within the scatter of the next, the first and the last beyond it).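

In this assay, the exchange of 4-fluorophenyl for 2,4-dichlorophenyl stays within the scatter (a 1.4-fold higher number from compound 3 to compound 4 (0.15 log units; within the scatter)), and so does the exchange of 4-bromophenyl for 2,4-dichlorophenyl (a 1.6-fold higher number from compound 1 to compound 4 (0.19 log units; within the scatter)). The earlier compounds shown here showed only one halogen swapped for another at this place, whereas these steps show that a second halogen, with both chlorines in place of a single fluorine or bromine, also gives no step beyond the scatter among compounds 1, 3 and 4. No measurement is available that would explain these numbers.

The compounds shown leave open whether a group other than a halogenated phenyl at this place, such as a methoxyphenyl, an aminophenyl or a carboxylic acid on the phenyl ring, would give a step beyond the scatter. Going by these compounds alone, they also leave open what the nitro group contributes, since compound 2, the only compound without it, differs from the others in more than one place.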